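Tert-butylphenyl thioether variant of the cinnamamide series

This account rests on a few compounds, and the source may have more. Where it says the series, first, only, none or still open, it means among the compounds named here.

Compound 1 `COc1ccc(SCc2ccc(/C=C/C(=O)Nc3ccccc3N)cc2)cc1OC` is the weakest point so far in a functional assay on HeLa cells (Homo sapiens) for inhibition, read by CCK-8 assay, with a stated time of 72 h, tested at 2 uM (a higher number here means more inhibition of growth at the concentration tested, a lower number less inhibition of growth), where compound 1 gives 10.1%. Compound 3 `Nc1ccccc1NC(=O)c1ccc(CSc2ccc(Br)cc2)cc1` gives 18.8% in this assay, a value within scatter of compound 1, while compound 2 `COc1ccc(SCc2ccc(C(=O)Nc3ccccc3N)cc2)cc1` gives 35%, clearly higher. Compound 4 `CC(C)(C)c1ccc(SCc2ccc(/C=C/C(=O)Nc3ccccc3N)cc2)cc1` differs from compound 1 only in that (4-(tert-butyl)phenyl in place of 3,4-dimethoxyphenyl on a sulfur). Within the data shown here, the one measured step that touches the aryl on the sulfur, a number 16.2 percentage points lower from compound 2 to compound 3 (beyond the scatter), was a modest drop, but it runs on a core without the two-carbon linker and swaps different groups, so it guides only loosely. A small step is expected, a number 4.9 percentage points higher from compound 1 to compound 4 (within the scatter), with no firm direction beyond the scatter. Compound 4 is therefore estimated at 15%, with a range of 4% to 30%.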

Compound 4, percent growth inhibition at one concentration: 17.5%
Compound 4: middle estimate off by 2.5 percentage points, on the low side, within the range that was stated.
By their numbers in this assay, from the lowest: compounds 1, 4 and 3 (each within the scatter of the next); then compound 2.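

In this assay, 4-(tert-butyl)phenyl in place of 3,4-dimethoxyphenyl on a sulfur gives a number 7.4 percentage points higher from compound 1 to compound 4 (within the scatter), the only step shown at this place on the core of compound 1. The entering group counts 0 hydrogen-bond acceptors against 2 in the leaving group, yet the two compounds are not separated beyond the scatter. No measurement shown here gives a reason for this result.

Open, going by these compounds, is whether an amine or a carboxylic acid on this aromatic ring would separate from compound 1 beyond the scatter. Also open, on these data alone, is how bromo would read on this core.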